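Coumarin series: ethylamino replacing chloro at the lactone ring

This account rests on a few compounds, and the source may have more. Where it says the series, first, only, none or still open, it means among the compounds named here.

Measured so far in an assay on isolated protein (strain Sprague-Dawley) for inhibition of Amine oxidase [flavin-containing] B (Rattus norvegicus), read by spectrophotometry, with a stated time of 5 min; on this read-out higher numbers stand for weaker inhibition and lower numbers for stronger inhibition:
compound 1 `CCOc1cc(=O)oc2cc(OCc3cccc(Cl)c3)ccc12` gives 115 nM
compound 2 `NC(=O)COc1cc(=O)oc2cc(OCc3cccc(Cl)c3)ccc12` gives 3.1 nM; 3.31 nM (2 entries)
compound 3 `O=c1cc(Cl)c2ccc(OCc3cccc(Cl)c3)cc2o1` gives 20.9 nM

Compound 3 carries the lowest of the two single numbers in this assay; its nearest neighbour is compound 1, and a 5.5-fold lower number from compound 1 to compound 3 (0.74 log units; beyond the scatter). Compound 2 sits apart from both, with several entries recorded (the several entries of compound 2 in this assay, 3.1 nM; 3.31 nM (2 entries)), all of them below the number for compound 3.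

Compound 4 `CCNc1cc(=O)oc2cc(OCc3cccc(Cl)c3)ccc12` is the next member, not yet measured in this assay. It differs from compound 3 in one place: ethylamino in place of chloro on an aromatic carbon.

Within the data shown here, only one measured step touches this position, the replacement of ethoxy by chloro from compound 1 to compound 3, which gave a modest change beyond the scatter. Compound 4 reverses the direction of that step in spirit, putting a three-atom chain back in place of the single chlorine, so a move back toward the number of compound 1 is the expectation, though the low numbers of compound 2 show that a larger group at this ring can also give a low number. On that basis compound 4 is expected to show a 2.4-fold higher number from compound 3 to compound 4 (0.38 log units; beyond the scatter) in this assay. The estimate for compound 4 is 50 nM, with a range from 10 nM to 250 nM.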

Compound 4, half-maximal inhibitory concentration: 28.2 nM
For compound 4 the middle estimate is 1.8-fold (0.25 log units) above the measured one, and the stated range covers the measured number.
By their numbers in this assay, from the lowest: compounds 3 and 4 (each within the scatter of the next); then compound 1.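

In this assay, ethylamino in place of chloro gives a 1.3-fold higher number from compound 3 to compound 4 (0.13 log units; within the scatter), so at this place, opposite the ring oxygen, the two groups are not separated, even though ethylamino brings a hydrogen-bond donor and chloro brings none. The earlier step from ethoxy to chloro left open whether any group larger than chloro would return to the number of compound 1, and the new result answers that for this one group: a 4.1-fold lower number from compound 1 to compound 4 (0.61 log units; beyond the scatter). With the ethyl part kept, exchanging the ethoxy group for ethylamino is therefore a step beyond the scatter, whereas exchanging chloro for ethylamino is not.

As far as these compounds go, whether the hydrogen on the ethylamino nitrogen matters stays open, and a dimethylamino group at this place would test it, while a free amino group or a longer chain such as butylamino would show how far the number follows the size of the group. Also open is which features of the side chain in compound 2 set it apart from ethylamino, as its numbers lie below those of compound 3 and compound 4: the several entries of compound 2 in this assay, 3.1 nM; 3.31 nM (2 entries)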